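The source may hold more compounds than are shown below. What is called first, only, known or untested is meant among the compounds shown, and "the series" means these compounds.

Compound 1 `Cc1ccc(SCc2ccc(/C=C/C(=O)Nc3ccccc3N)cc2)cc1` gives 25.5% in a functional assay on HeLa cells (Homo sapiens) for inhibition, read by CCK-8 assay, with a stated time of 72 h, tested at 2 uM; a lower number here means less inhibition of growth, a higher number more inhibition of growth at the concentration tested.
Compound 2 `Nc1ccccc1NC(=O)c1ccc(CSc2ccc(C(F)(F)F)cn2)cc1` gives 11.5% in this assay.

Of these two numbers, compound 1 stands highest; compound 2 comes in lower, and the gap between them lies beyond the usual scatter. The two compounds differ in several places at once, so nothing beyond those two values can be said of that pair.

Compound 3 `Cc1cc(C)cc(SCc2ccc(/C=C/C(=O)Nc3ccccc3N)cc2)c1` has not yet been measured. It keeps the core of compound 1 and changes one group: 3,5-dimethylphenyl in place of 4-methylphenyl on a sulfur. The group that leaves and the one that enters are close relatives, each an aromatic ring of carbon only, differing just in their methyl groups. For the measured compounds named here, no measured pair shows what such a swap does here, so the step in this assay is expected to be small, in either direction, and not clearly beyond the scatter. Compound 3 is therefore expected to give about 27%, within a range of 12% to 42%. This estimate means an expected step of a number 1.5 percentage points higher from compound 1 to compound 3 (within the scatter).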

Compound 3, percent growth inhibition at one concentration: 11.7%
Beside the measured number, compound 3's estimate is 15.3 percentage points above it, and the stated range ends above it.
By their numbers in this assay, from the lowest: compounds 2 and 3 (each within the scatter of the next); then compound 1.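

For the compounds shown here, this pair is the first in this assay to differ in one place only, and it shows that the group on the sulfur matters: 3,5-dimethylphenyl in place of 4-methylphenyl gives a number 13.8 percentage points lower from compound 1 to compound 3 (beyond the scatter), so growth inhibition falls. Even a swap between close relatives, each an aromatic ring of carbon only, can therefore produce a step beyond the scatter on this core. No measurement here accounts for that step.

As far as these compounds go, whether a plain phenyl group, or a ring carrying a chlorine atom or a methoxy group, would give a number closer to compound 1 or to compound 3 remains open. Also open, from the compounds shown here alone, is whether this single pair reflects a wider trend among groups on the sulfur, or holds at other concentrations.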